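Cytotoxicity limits in a dimethoxybenzamide anilide series

A few compounds are considered here, and "the series" means these few. Any claim that something is new, unique, unknown or untested is made for them only; others in the source may bear on it.

Measured compounds:
- compound 1 `COc1ccc(C(=O)Nc2ccc(Cl)cc2F)c(OC)c1`: in an ADME assay on RAW264.7 cells (Mus musculus) for cytotoxicity, read by MTT assay, with a stated time of 24 h (on this read-out lower numbers stand for higher toxicity in this test and higher numbers for lower toxicity in this test), compound 1 gives 13600 nM.
- compound 2 `COc1ccc(C(=O)Nc2ccc(Cl)cc2F)c(OCc2ccc(F)cc2F)c1`: in this assay compound 2 gives > 40000 nM, which is a limit of the assay and not a number.
- compound 3 `COc1ccc(C(=O)Nc2ccc(I)cc2F)c(OC)c1`: in this assay compound 3 gives > 40000 nM, likewise a limit of the assay.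

Going by the values given here, compound 1 is the only member with a numerical reading. The change to compound 2 is 2,4-difluorophenyl in place of hydrogen on a saturated chain carbon bound to an oxygen on an aromatic ring; it gives an at least 2.9-fold higher number from compound 1 to compound 2 (0.46 log units; beyond the scatter). The change to compound 3 is iodo in place of chloro on an aromatic carbon; it gives an at least 2.9-fold higher number from compound 1 to compound 3 (0.46 log units; beyond the scatter). Going by these compounds, both steps are open-ended due to the limit of > 40000 nM in this assay, at which 2 of the 3 values shown sit, so their true size is unknown beyond being at least modest.

Compound 4 `COc1ccc(C(=O)Nc2ccc(I)cc2F)c(OCc2ccc(F)cc2F)c1` is not yet measured. It differs from compound 3 by 2,4-difluorophenyl in place of hydrogen on a saturated chain carbon bound to an oxygen on an aromatic ring, the same change as was made from compound 1 to compound 2, and at the same place. The two cores differ by iodo in place of chloro on an aromatic carbon.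

Since compound 3 already sits at a limit, and the same change on the core of compound 1 raised the reading to a limit, the reading for compound 4 is expected to remain at a limit; the step is estimated as a step that the limit leaves unreadable from compound 3 to compound 4, resting on an at least 2.9-fold higher number from compound 1 to compound 2 (0.46 log units; beyond the scatter) and on the limit of compound 3, > 40000 nM. For compound 4 the estimate in this assay is 60000 nM, with a range from 30000 nM to 150000 nM.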

Compound 4, half-maximal cytotoxic concentration: 36800 nM
Beside the measured number, compound 4's estimate is 1.6-fold (0.21 log units) above it, within the range that was stated.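

Placed on the core of compound 3, the 2,4-difluorophenyl change gives an at least 1.0-fold lower number from compound 3 to compound 4 (0.03 log units; that floor lies within the scatter) in this assay, so it does not carry over from the core of compound 1 at the size seen there: the same change on two cores in this assay, an at least 2.9-fold higher number (0.46 log units; beyond the scatter) from compound 1 to compound 2 and an at least 1.0-fold lower number (0.03 log units; that floor lies within the scatter) from compound 3 to compound 4, at least 3.1-fold (0.50 log units) apart, beyond the scatter of two such steps

The iodo in place of chloro change behaves the same way, giving an at least 1.0-fold lower number from compound 2 to compound 4 (0.03 log units; that floor lies within the scatter) once the 2,4-difluorobenzyl group is present, so neither change acts as a fixed increment across these two cores: the same change on two cores in this assay, an at least 2.9-fold higher number (0.46 log units; beyond the scatter) from compound 1 to compound 3 and an at least 1.0-fold lower number (0.03 log units; that floor lies within the scatter) from compound 2 to compound 4, at least 3.1-fold (0.50 log units) apart, beyond the scatter of two such steps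

Both new steps are only floors, so the notes show that the two changes do not add up simply, but not how large either new step really is, nor whether it is a real fall in the reading at all: the limit of > 40000 nM in this assay, at which 2 of the 4 values shown sit.

The compounds shown leave open whether a plain benzyl group without fluorine, or a longer chain such as ethyl or propyl in place of methyl, would follow compound 2 or compound 4 on these cores. They also leave open how bromo in place of chloro or iodo would read, and whether an amine or a carboxylic acid on the benzyl ring would change the picture.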